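The compounds below may be only part of what the source reports. "The series", "measured", "known", "first", "only" and "open" are said of these compounds alone.

Of the compounds shown here, two of a shared core have been measured in an assay for displacement of a labelled ligand from corticotropin-releasing factor receptor 1 (Homo sapiens); a higher number here means a weaker inhibitor, a lower number a stronger inhibitor. Compound 1 `CCCN(Cc1sc(Nc2c(Br)cc(C)cc2Br)nc1C(F)(F)F)CC1CC1` gives 28 nM. Compound 2 `CCCN(Cc1sc(Nc2c(C)cc(Cl)cc2C)nc1C(F)(F)F)CC1CC1` gives 73 nM, the higher of the two numbers, and the step of a 2.6-fold higher number from compound 1 to compound 2 (0.42 log units; beyond the scatter) separates them, so compound 2 is the weaker binder of the measured pair. Compound 3 `CCCN(Cc1sc(Nc2c(Br)cc(Br)cc2Br)nc1C(F)(F)F)CC1CC1` has not yet been measured; it differs from compound 2 in one place: 2,4,6-tribromophenyl in place of 4-chloro-2,6-dimethylphenyl on a nitrogen on an aromatic ring. Going by the values given here, the only measured step that bears on this change is the step from compound 1 to compound 2, where exchanging two bromines and a methyl for two methyls and a chlorine on the same phenyl ring raised the number modestly. Compound 3 returns to bromine at the two positions where compound 1 carried it and adds a third bromine where compound 1 carried methyl. The expectation is therefore a step back toward the number of compound 1, estimated as a 2.1-fold lower number from compound 2 to compound 3 (0.32 log units; beyond the scatter). The estimated value for compound 3 in this assay is 35 nM, with a range from 12 nM to 100 nM.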

Compound 3, inhibition constant: 7.8 nM
Beside the measured number, compound 3's estimate is 4.5-fold (0.65 log units) above it; the whole stated range lies above it.
By their numbers in this assay, from the lowest: compound 3; then compound 1; then compound 2.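

In this assay, 2,4,6-tribromophenyl in place of 4-chloro-2,6-dimethylphenyl on the nitrogen gives a 9.4-fold lower number from compound 2 to compound 3 (0.97 log units; beyond the scatter) and makes compound 3 the strongest binder of the three. The two groups have the same count of heavy atoms and neither has a hydrogen-bond donor or acceptor, so those counts do not separate them, yet the number still moves clearly. The earlier pair changed all the ring substituents at once, whereas bromo in place of methyl on a single aromatic carbon, with the rest of the molecule unchanged, now gives a 3.6-fold lower number from compound 1 to compound 3 (0.56 log units; beyond the scatter), which shows that this one exchange on the ring counts on its own.

No measurement here explains why bromine at this place goes with the lower number. As far as these compounds go, it remains open whether the gain is specific to bromine or would also appear with an iodo group, a nitrile or a methoxy group on that same aromatic carbon, and whether it would hold if the propyl and cyclopropylmethyl groups of the shared core were replaced by a longer chain.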